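Compound 4 Against a Series Sitting at the Assay Ceiling

A few compounds are considered here, and "the series" means these few. Any claim that something is new, unique, unknown or untested is made for them only; others in the source may bear on it.

Compound 1 `CC(=O)Oc1ccc(C(=O)Nc2cc3ccc(Oc4ccc(C(C)(C)C)cc4)c(C)c3oc2=O)cc1CC=C(C)C` in a functional assay on MCF7 cells (Homo sapiens) for antiproliferative activity (on this read-out lower numbers stand for stronger inhibition and higher numbers for weaker inhibition), gives 75000 nM. Compound 2 `COc1ccc(Nc2ccc3cc(NC(=O)c4ccc(OC(C)=O)c(CC=C(C)C)c4)c(=O)oc3c2C)cc1` in this assay reaches only a limit, > 100000 nM. Compound 3 `COc1ccc(Nc2ccc3cc(NC(=O)c4ccc(O)c(CC=C(C)C)c4)c(=O)oc3c2C)cc1` in this assay likewise reaches only a limit, > 100000 nM.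

Compound 3 thus stands at the ceiling of the numbers shown, sharing the limit of > 100000 nM in this assay, at which 2 of the 3 values shown sit, with compound 2. Compound 4 `COc1cc(Cc2ccc3cc(NC(=O)c4ccc(O)c(CC=C(C)C)c4)c(=O)oc3c2C)ccc1O` differs from compound 3 in one place: 4-hydroxy-3-methoxybenzyl in place of (4-methoxyphenyl)amino on an aromatic carbon. Going by the values given here, no measured step makes this exchange. Among the compounds with values here, the nearest precedent, an at least 1.3-fold higher number from compound 1 to compound 2 (0.12 log units; that floor lies within the scatter), changed the group on the same aromatic carbon; the other step, a step that the two limits leave unreadable from compound 2 to compound 3, concerned a different site. Neither gives a readable direction. Compound 4 is therefore expected to remain near the limit, the step of a number no higher from compound 3 to compound 4 (the limit leaves the size open) estimated as none beyond the scatter. Compound 4 is estimated at 100000 nM, between 30000 nM and 300000 nM.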

Compound 4, half-maximal inhibitory concentration: 14600 nM
Beside the measured number, compound 4's estimate is 6.8-fold (0.84 log units) above it; the measured number lies below the stated range.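

In this assay, the aromatic carbon ortho to a methyl group now proves able to move the read-out beyond the scatter: 4-hydroxy-3-methoxybenzyl in place of (4-methoxyphenyl)amino gives an at least 6.8-fold lower number from compound 3 to compound 4 (0.83 log units; beyond the scatter) with the rest of the molecule unchanged. The earlier exchange on this carbon stayed within the scatter, and the step at the acetyl oxygen cannot be read. The new step is only a floor, as compound 3 rests on a limit: the limit of > 100000 nM in this assay, at which 2 of the 4 values shown sit.

The compounds shown leave open whether the methylene link or the hydroxy and methoxy groups carry this step. On these data alone, whether plain benzyl or a carboxylic acid on the benzyl ring would keep it also remains open.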